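The source may hold more compounds than are shown below. What is called first, only, known or untested is meant among the compounds shown, and "the series" means these compounds.

Of the compounds shown here, three have been measured in a functional assay on HT-1080 cells (Homo sapiens) for cytotoxicity, read by MTT assay, with a stated time of 24 h; on this read-out lower numbers stand for an effect already at smaller amounts and higher numbers for an effect only at larger amounts of compound. Compound 1 `C=C1CC[C@@H]2[C@](C)(CCC[C@]2(C)C(=O)O)[C@H]1CC/C(C)=C/COC(C)=O` gives 70.1 ug/mL. Compound 2 `C=C1CC[C@@H]2[C@](C)(CCC[C@]2(C)C(=O)O)[C@H]1CC/C(C)=C/C(=O)O` gives 75.4 ug/mL. Compound 3 `C=C1CC[C@@H]2[C@](C)(CCC[C@]2(C)C(=O)O)[C@H]1CC/C(C)=C/C(=O)OC` gives 72.8 ug/mL.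

Compound 3 holds the second highest of the three numbers; the nearest of the others is reached by a 1.0-fold lower number from compound 2 to compound 3 (0.02 log units; within the scatter), the furthest by a 1.0-fold higher number from compound 1 to compound 3 (0.02 log units; within the scatter). Compound 4 `C=C[C@](C)(O)CC[C@H]1C(=C)CC[C@@H]2[C@]1(C)CCC[C@]2(C)C(=O)O` differs from compound 3 in one place: 1-hydroxy-1-methylprop-2-en-1-yl in place of 2-(methoxycarbonyl)-1-methylethenyl on a saturated chain carbon, two bonds along the chain from a saturated ring carbon. All three measured steps alter the same chain end, a 1.1-fold higher number from compound 1 to compound 2 (0.03 log units; within the scatter) as well as the two already given, and each stays within the scatter. The change to compound 4 goes further than any of them, but nothing measured points in either direction, so no step beyond the scatter is expected: a 1.0-fold higher number from compound 3 to compound 4 (0.00 log units; within the scatter). Compound 4 is therefore estimated at 73 ug/mL, in a range from 35 ug/mL to 150 ug/mL.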

Compound 4, concentration for half-maximal effect: 94.9 ug/mL
Estimate against measurement, compound 4: 1.3-fold (0.11 log units) below; low and high end bracket the measured number.
By their numbers in this assay, from the lowest: compounds 1, 3, 2 and 4 (each within the scatter of the next).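

In this assay, the chain end of compound 4 differs from the other three, yet there is a 1.3-fold higher number from compound 3 to compound 4 (0.12 log units; within the scatter) and a 1.3-fold higher number from compound 2 to compound 4 (0.10 log units; within the scatter) as well as (a 1.4-fold higher number from compound 1 to compound 4 (0.13 log units; within the scatter)). On a saturated chain carbon, two bonds along the chain from a saturated ring carbon, even the larger exchange for 1-hydroxy-1-methylprop-2-en-1-yl therefore leaves the number within the scatter of all three earlier compounds. Nothing measured explains these numbers. As far as these compounds go, whether an amine or a longer chain at this place would produce a step beyond the scatter remains open.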